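Swapping 4-chlorophenyl for 3-fluorophenyl: a small step expected

The source may report more compounds than this note shows. Statements on the series, on what has been measured and on what is new or still open speak of the compounds shown alone.

In a functional assay on A549 cells (Homo sapiens) for antiproliferative activity, read by MTT assay, with a stated time of 48 h (on this read-out lower numbers stand for stronger inhibition and higher numbers for weaker inhibition), compound 1 `COc1ccc(C(=O)Nc2nnc(/C=C/c3cc(OC)c(OC)c(OC)c3Br)s2)cc1` gives 150 nM and compound 2 `COc1cc(/C=C/c2nnc(NC(=O)c3ccc(Cl)cc3)s2)c(Br)c(OC)c1OC` gives 140 nM. These two values lie within the scatter of each other, so neither compound can be ranked above the other. Compound 3 `COc1cc(/C=C/c2nnc(NC(=O)c3cccc(F)c3)s2)c(Br)c(OC)c1OC` has not yet been measured. It differs from compound 2 in one place: 3-fluorophenyl in place of 4-chlorophenyl on a carbonyl carbon. That is, 3-fluorophenyl stands in place of 4-chlorophenyl on a carbonyl carbon. Going by the values given here, only one measured step bears on this change: a 1.1-fold lower number from compound 1 to compound 2 (0.03 log units; within the scatter), with chloro in place of methoxy on an aromatic carbon. Among the compounds with values here, it is a single step, and no measured compound carries fluorine, so the evidence is thin. Even so, no step beyond the scatter is expected in this assay. The estimated change is a 1.1-fold higher number from compound 2 to compound 3 (0.06 log units; within the scatter). For compound 3 the expected value is 160 nM, with an estimated range of 70 nM to 380 nM.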

Compound 3, half-maximal inhibitory concentration: 80 nM
Beside the measured number, compound 3's estimate is 2.0-fold (0.30 log units) above it; measured number inside the range.
By their numbers in this assay, from the lowest: compounds 3, 2 and 1 (each within the scatter of the next).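

In this assay, the group on the carbonyl carbon now comes in three forms, 4-methoxyphenyl, 4-chlorophenyl and 3-fluorophenyl, on an otherwise shared core. Both new steps, a 1.8-fold lower number from compound 2 to compound 3 (0.24 log units; within the scatter) and a 1.9-fold lower number from compound 1 to compound 3 (0.27 log units; within the scatter), lie within the scatter, so these three compounds cannot be ranked. Going by these compounds alone, this adds something the earlier pair did not show: a change in both the halogen and its printed ring position, from 4-chlorophenyl to 3-fluorophenyl, gives no step that can be told apart from repeat-measurement variation.

Still open, from the compounds shown here alone, is whether an amine or a carboxylic acid on this ring, or a longer chain in its place, would give a step beyond the scatter. With 4-fluorophenyl and 3-chlorophenyl absent from the compounds shown, the halogen and its ring position also cannot be judged separately. No measurement available here offers an explanation for these results.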